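Thiosemicarbazone series: nitro for chloro on the aryl ring

This account rests on a few compounds, and the source may have more. Where it says the series, first, only, none or still open, it means among the compounds named here.

Compound 1 `CC1=CC[C@H](C(C)(C)NC(=S)N/N=C/c2ccccc2Cl)CC1` gives 5600 nM in a functional assay on K562 cells (Homo sapiens) for inhibition, read by sulforhodamine B assay, with a stated time of 48 h; a higher number here means a weaker inhibitor of growth, a lower number a stronger inhibitor of growth. Compound 2 `CC1=CC[C@H](C(C)(C)NC(=S)N/N=C/c2cccc(Cl)c2)CC1` gives 5400 nM in this assay; the two cores differ as 3-chlorophenyl in place of 2-chlorophenyl on a carbon with a double bond to nitrogen, and the step is a 1.0-fold lower number from compound 1 to compound 2 (0.02 log units; within the scatter). Compound 3 `CC1=CC[C@H](C(C)(C)NC(=S)N/N=C/c2ccccc2[N+](=O)[O-])CC1` gives 300 nM in this assay; its change from compound 1 is nitro in place of chloro on an aromatic carbon, and the step is a 19-fold lower number from compound 1 to compound 3 (1.27 log units; beyond the scatter). Compound 4 `CC1=CC[C@H](C(C)(C)NC(=S)N/N=C/c2cccc([N+](=O)[O-])c2)CC1` is not yet measured in this assay. It differs from compound 2 as nitro in place of chloro on an aromatic carbon, the same kind of change as before, but in compound 3 the nitro sits ortho to a large group, whereas in compound 4 it sits meta to a large group. The step is expected to be an 11-fold lower number from compound 2 to compound 4 (1.03 log units; beyond the scatter), judged from a 19-fold lower number from compound 1 to compound 3 (1.27 log units; beyond the scatter) with allowance for the different place. Compound 4 is thus estimated at 500 nM, between 150 nM and 2000 nM.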

Compound 4, concentration for 50% growth inhibition: 45600 nM
For compound 4 the middle estimate is 91-fold (1.96 log units) below the measured one; measured number above the stated range.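

In this assay, nitro in place of chloro gives an 8.4-fold higher number from compound 2 to compound 4 (0.93 log units; beyond the scatter). Set beside the earlier step, the same change runs in opposite directions on the two cores: the same change on two cores in this assay, a 19-fold lower number (1.27 log units; beyond the scatter) from compound 1 to compound 3 and an 8.4-fold higher number (0.93 log units; beyond the scatter) from compound 2 to compound 4, 160-fold (2.20 log units) apart, beyond the scatter of two such steps. The effect of this change therefore cannot be carried from the core of compound 1 to the core of compound 2 in this series, but two pairs do not show what separates the two results or give a rule for other groups.

Going by these compounds, it remains open whether an amine, a methoxy group or a carboxylic acid on the same aromatic carbon would follow the chloro or the nitro compounds. On these data alone, it also remains open whether the split between the two cores would hold for any group other than nitro.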